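Three Ring Stereocentres Inverted in a Compound with a Low Number in This Assay

This account rests on a few compounds, and the source may have more. Where it says the series, first, only, none or still open, it means among the compounds named here.

Compound 1, `O=C(O)[C@@H]1NC[C@@H](O)[C@@H](O)[C@H]1O`, is a sugar-like ring bearing a ring nitrogen, three hydroxyl groups and a carboxylic acid. In an assay for inhibition of alpha-N-acetylgalactosaminidase (Gallus gallus), tested at 1000 uM (on this read-out higher numbers stand for more inhibition at the one concentration tested (going by the name of the read-out) and lower numbers for less inhibition), compound 1 gives 8.2%. Compound 2, `O=C(O)[C@@H]1NC[C@@H](O)[C@H](O)[C@H]1O`, shares every atom and bond with compound 1 and differs only in the configuration drawn at one saturated ring carbon. In this assay compound 2 gives 1.3%; of the two numbers shown it is the smaller, but the step of a number 6.9 percentage points lower from compound 1 to compound 2 (within the scatter), so the two compounds cannot be told apart. Among the measured compounds shown here, the only evidence for that step is the fact that compounds 1 and 2 differ only in the configuration as drawn.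

Compound 3, `O=C(O)[C@H]1NC[C@H](O)[C@H](O)[C@@H]1O`, keeps the same atoms and bonds again, and (the two compounds have the same atoms and bonds and differ only in configuration as drawn: 3 of 4 stereo elements differ; a stereocentre at a saturated ring carbon is drawn R in compound 2 and S in compound 3; a stereocentre at a saturated ring carbon is drawn R in compound 2 and S in compound 3; a stereocentre at a saturated ring carbon is drawn S in compound 2 and R in compound 3). For the measured compounds named here, the single measured step that bears on such a change, the inversion of one ring stereocentre, stayed within the scatter, and both measured compounds sit low in this assay. For compound 3 the expected step is therefore a number 3.7 percentage points higher from compound 2 to compound 3 (within the scatter), nothing beyond the scatter. Compound 3 is estimated to give 5%, within a range from 0% to 25%.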

Compound 3, a percentage reported as inhibition, at one concentration (the size of the read-out at that concentration, not a potency): 4.5%
Beside the measured number, compound 3's estimate is 0.5 percentage points above it; the measured number falls inside the stated range.
By their numbers in this assay, from the lowest: compounds 2, 3 and 1 (each within the scatter of the next).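

Changing three ring stereocentres at once leaves the read-out in this assay within the scatter, as the change at one stereocentre did, with a number 3.2 percentage points higher from compound 2 to compound 3 (within the scatter). Among the compounds shown here, the mirror-image pair gives the same picture, with a number 3.7 percentage points lower from compound 1 to compound 3 (within the scatter), so even inverting all four stereocentres yields no step that can be told from the scatter. No arrangement among the three compounds stands apart in this assay, and the comparison rests on a single kind of difference: the fact that compounds 1 and 3 differ only in the configuration as drawn

On these data alone, all three numbers sit low, so it remains open whether any configuration of the shared core would give clear inhibition at the one concentration tested, and a small effect of configuration could lie hidden inside the scatter. As far as these compounds go, it also remains open how the number would respond if an amide took the place of the carboxylic acid, or if a longer chain were carried on the ring nitrogen.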